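Extending the chain on compound 2 to decyl

A few compounds are considered here, and "the series" means these few. Any claim that something is new, unique, unknown or untested is made for them only; others in the source may bear on it.

In a functional assay on U-118-MG cells (Homo sapiens) for cytotoxicity, read by MTT assay, with a stated time of 48 h (a lower number here means a stronger inhibitor, a higher number a weaker inhibitor), compound 1 `CCOC(=O)C[n+]1cccc(O)c1` reads > 200000 nM, which is a limit of the assay and not a number. Going by the values given here, compound 2 `C[n+]1cccc(OP(=O)([O-])OC[C@H]2O[C@@H](n3cc(F)c(=O)[nH]c3=O)C[C@@H]2OC(=O)c2ccccc2)c1` gives 3150 nM, the only actual number so far. Compound 3 `CCCCCCCCCC[n+]1cccc(OP(=O)([O-])OC[C@H]2O[C@@H](n3cc(F)c(=O)[nH]c3=O)C[C@@H]2OC(=O)c2ccccc2)c1` carries nonyl in place of hydrogen on a saturated chain carbon bound to an aromatic nitrogen, which reads as methyl to decyl. Among the compounds with values here, no measured step covers this change, so the expectation is tentative. The expected step is a 3.2-fold lower number from compound 2 to compound 3 (0.50 log units; beyond the scatter), toward stronger inhibition and beyond the scatter. For compound 3 the estimated value is 1000 nM, with an expected range of 200 nM to 5000 nM.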

Compound 3, half-maximal inhibitory concentration: 320 nM
Compound 3: middle estimate off by 3.1-fold (0.49 log units), on the high side, within the range that was stated.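

In this assay, the saturated chain carbon bound to an aromatic nitrogen accepts a large change: nonyl in place of hydrogen gives a 9.8-fold lower number from compound 2 to compound 3 (0.99 log units; beyond the scatter) and moves toward stronger inhibition, beyond the scatter. Going by these compounds alone, this is the first measured step, so the decyl chain is now known to keep the activity of compound 2 and to improve on it. Nothing shown accounts for the size of this step. Open, going by these compounds, are the intermediate chains between methyl and decyl, a longer chain such as dodecyl, and a decyl chain ending in an amine or a carboxylic acid.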